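The compounds below may be only part of what the source reports. "The series", "measured", "known", "first", "only" and "open" are said of these compounds alone.

Measured compounds:
compound 1 `COc1ccc(C2OC(c3cc(OC)c(OC)c(OC)c3)=NN2C(C)=O)c(OC)c1`: 69.5%
compound 2 `COc1cccc(/C=N/NC(=O)c2cc(OC)c(OC)c(OC)c2)c1OC`: 53.2%

In a functional assay on PC-3 cells (Homo sapiens) for antiproliferative activity, read by MTT assay, tested at 1 uM (on this read-out lower numbers stand for a weaker effect and higher numbers for a stronger effect at the one concentration tested), compound 1 gives 69.5%, the higher of the two numbers available. Compound 2 gives 53.2% in this assay, and the gap to compound 1 lies beyond the usual scatter, so compound 1 is the stronger of the pair on this read-out. Going by the values given here, no single-place step links the two measured compounds, so neither number says how a change at one site would shift the result.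

Compound 3 `COc1cc(C2=NN(C(C)=O)C(c3cccc(F)c3)O2)cc(OC)c1OC` has not yet been tested in this assay. It differs from compound 1 in one place: 3-fluorophenyl in place of 2,4-dimethoxyphenyl on a saturated ring carbon. Both groups share one six-membered aromatic ring of carbon only; 2,4-dimethoxyphenyl brings two hydrogen-bond acceptors, 3-fluorophenyl none. Among the compounds with values here, no measured pair shows a change of this kind, so direction and size can only be guessed. The writer expects for compound 3 a small loss, roughly at the edge of the scatter, with the step of a number 11.5 percentage points lower from compound 1 to compound 3 (beyond the scatter). For compound 3 the estimate in this assay is 58%, with a range from 35% to 78%.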

Compound 3, a percentage reported as inhibition, at one concentration (the size of the read-out at that concentration, not a potency): 16.5%
Compound 3: middle estimate off by 41.5 percentage points, on the high side, outside the stated range (below it).
By their numbers in this assay, from the lowest: compound 3; then compound 2; then compound 1.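

Going by these compounds alone, the first single-place step in this set falls at the saturated ring carbon: in this assay, putting 3-fluorophenyl in place of 2,4-dimethoxyphenyl gives a number 53 percentage points lower from compound 1 to compound 3 (beyond the scatter), a large change. The result shows that the aryl group at this position strongly affects the read-out, even though the shared core and its acetyl group stay the same and both groups contain one six-membered aromatic ring of carbon only. The change removes the two hydrogen-bond acceptors counted on 2,4-dimethoxyphenyl, but nothing available explains the size of the step.

Because this one step exchanges the whole aryl group, it leaves open whether the loss follows from losing the methoxy groups, from gaining the fluorine, or from both together. It also leaves open how the same position would respond to an unsubstituted phenyl, a pyridyl or a 4-hydroxyphenyl, any of which could help separate these possibilities and show whether the number can be recovered.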